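Notes on a vinyl-ended chain in the series

The compounds below may be only part of what the source reports. "The series", "measured", "known", "first", "only" and "open" are said of these compounds alone.

Compound 1 `CCCCCCCCCC(=O)Nc1nnc(S[C@@H]2O[C@H](CO)[C@H](O)[C@H](O)[C@H]2O)s1`: 25900 nM
Compound 2 `CCCCCCCC/C=C\CCCCCCCCCCCC(=O)Nc1nnc(S[C@@H]2O[C@H](CO)[C@H](O)[C@H](O)[C@H]2O)s1`: 13500 nM

Among the measured compounds shown here, in a functional assay on HeLa cells (Homo sapiens) for cytotoxicity, read by MTT assay, with a stated time of 24 h (a higher number here means a weaker inhibitor, a lower number a stronger inhibitor), compound 1 gives 25900 nM, and the only other measured compound lies within the scatter of it: a 1.9-fold lower number from compound 1 to compound 2 (0.28 log units; within the scatter). Compound 3 `C=CCCCCCCCCC(=O)Nc1nnc(S[C@@H]2O[C@H](CO)[C@H](O)[C@H](O)[C@H]2O)s1` differs from compound 1 by vinyl in place of methyl on a saturated chain carbon, eight bonds along the chain from a carbonyl carbon. For the measured compounds named here, the single measured chain change, a 1.9-fold lower number from compound 1 to compound 2 (0.28 log units; within the scatter), is the only guide, so no step beyond the scatter is expected in this assay. For compound 3 the estimated value is 22000 nM, with an expected range of 11000 nM to 45000 nM. The expected step is a 1.2-fold lower number from compound 1 to compound 3 (0.07 log units; within the scatter).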

Compound 3, half-maximal inhibitory concentration: 58300 nM
Compound 3: the middle estimate sits 2.7-fold (0.42 log units) below what was measured, and the stated range ends below it.
By their numbers in this assay, from the lowest: compounds 2 and 1 (each within the scatter of the next); then compound 3.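

In this assay, vinyl in place of methyl on a saturated chain carbon, eight bonds along the chain from a carbonyl carbon, gives a 2.3-fold higher number from compound 1 to compound 3 (0.35 log units; beyond the scatter), a modest step. Among the compounds shown here, the earlier chain change, a 1.9-fold lower number from compound 1 to compound 2 (0.28 log units; within the scatter), gave no such reading, so this position is the first to show a change beyond the scatter. Nothing at hand accounts for the step. On these data alone, whether the double bond or the added carbon carries it stays open. Ethyl at this place would separate the two, and a hydroxyl or an amine would probe the chain end further.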